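The source may hold more compounds than are shown below. What is called first, only, known or untested is meant among the compounds shown, and "the series" means these compounds.

Measured in a functional assay on SK-MEL-28 cells (Homo sapiens) for inhibition; a lower number here means a stronger inhibitor, a higher number a weaker inhibitor:
- compound 1 `FC(F)(F)c1ccc(/C=C/c2ccc3ccccc3c2)cc1`: > 5000 nM (a limit)
- compound 2 `FC(F)(F)c1ccc(/C=C\c2ccc3ccccc3c2)cc1`: > 5000 nM (a limit)

Compound 2 has no number, only a limit: the limit of > 5000 nM in this assay, at which 2 of the 2 values shown sit. Compound 3 `CN(C)c1ccc(/C=C\c2ccc3ccccc3c2)cc1` has dimethylamino in place of trifluoromethyl on an aromatic carbon, para to a large group: dimethylamino in place of trifluoromethyl on an aromatic carbon. Within the data shown here, the one measured step, a step that the two limits leave unreadable from compound 1 to compound 2, gives no size and concerns (the fact that compounds 1 and 2 differ only in the configuration as drawn), not a substituent. Compound 2 reads > 5000 nM, a limit, so only a step toward stronger inhibition could show. The expected step in this assay is an at least 1.6-fold lower number from compound 2 to compound 3 (0.22 log units; that floor lies within the scatter), a tentative estimate. Compound 3 is estimated at 3000 nM, with an expected range of 500 nM to 10000 nM.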

Compound 3, half-maximal inhibitory concentration: 3660 nM
The estimate for compound 3 lay 1.2-fold (0.09 log units) below the measured number, within the range that was stated.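

Among these compounds, with dimethylamino on an aromatic carbon, para to a large group, the series gains its only actual number: in this assay compound 3 gives 3660 nM. Compound 2 gives > 5000 nM, which is a limit. The change therefore reads only as an at least 1.3-fold lower number from compound 2 to compound 3 (0.13 log units; that floor lies within the scatter), so a lower number for compound 3 is not established beyond the scatter.

From the compounds shown here alone, the step between the two double-bond configurations cannot be read, so the effect of configuration with any group at this position remains open. Also open, going by these compounds, is how a primary amine or a carboxylic acid at this position would read.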